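Swapping the Aryl Group on the Carbonyl Carbon

A few compounds are considered here, and "the series" means these few. Any claim that something is new, unique, unknown or untested is made for them only; others in the source may bear on it.

Compound 1 `COc1ccc(C(=O)/C=C/c2cc(-c3cc(OC)c(OC)c(OC)c3)n[nH]2)cc1OC`: 5310 nM
Compound 2 `COc1ccc(C(=O)/C=C/c2cc(-c3cc(OC)c(OC)c(OC)c3)n[nH]2)cc1`: 5850 nM

In a functional assay on SF-539 cells (Homo sapiens) for inhibition, read by sulforhodamine B assay, with a stated time of 48 h (on this read-out higher numbers stand for lower toxicity in this test and lower numbers for higher toxicity in this test), compound 2 gives the higher of the two numbers, yet a 1.1-fold higher number from compound 1 to compound 2 (0.04 log units; within the scatter) stays within the scatter. Compound 3 `COc1cc(-c2cc(/C=C/C(=O)c3ccc(F)c(F)c3)[nH]n2)cc(OC)c1OC` differs from compound 2 by 3,4-difluorophenyl in place of 4-methoxyphenyl on a carbonyl carbon. For the measured compounds named here, no measured step involves this change; the single measured step, a 1.1-fold higher number from compound 1 to compound 2 (0.04 log units; within the scatter), concerned only a methoxy group and barely moved the number. The step to compound 3 is therefore expected to stay within the scatter: a 1.0-fold higher number from compound 2 to compound 3 (0.01 log units; within the scatter). The estimate for compound 3 is 6000 nM, with a range from 2000 nM to 18000 nM.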

Compound 3, concentration lethal to 50% of the cells: 70000 nM
Compound 3: the middle estimate sits 12-fold (1.07 log units) below what was measured; measured number above the stated range.
By their numbers in this assay, from the lowest: compounds 1 and 2 (each within the scatter of the next); then compound 3.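

Unlike the methoxy change seen earlier, swapping the whole aryl group on the carbonyl carbon moves the result sharply in this assay. Replacing 4-methoxyphenyl with 3,4-difluorophenyl gives a large change (a 12-fold higher number from compound 2 to compound 3 (1.08 log units; beyond the scatter)), and replacing 3,4-dimethoxyphenyl with it gives a similarly large one (a 13-fold higher number from compound 1 to compound 3 (1.12 log units; beyond the scatter)), leaving compound 3 the least toxic of the three in this test. No measurement here explains this shift. Going by these compounds, whether the rise comes from losing methoxy or from gaining fluorine stays open, as does how an aryl group carrying an amine or a carboxylic acid would read at this carbonyl carbon.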